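Methoxy pattern on the cinnamoyl aryl of the macrolactam series

A few compounds are considered here, and "the series" means these few. Any claim that something is new, unique, unknown or untested is made for them only; others in the source may bear on it.

Three members of the series share one core and differ only in the aryl group on a double-bonded chain carbon. Compound 1 `COc1ccc(/C=C/C(=O)c2ccc(OCCn3cc(CN4C(=O)/C=C/C(C)(C)C/C=C(\C)CC/C=C/4C)nn3)cc2O)cc1` carries 4-methoxyphenyl and gives 3.24 ug/mL in a functional assay on SW480 cells (Homo sapiens) for antiproliferative activity; a higher number here means a weaker inhibitor, a lower number a stronger inhibitor. Compound 2 `COc1cccc(/C=C/C(=O)c2ccc(OCCn3cc(CN4C(=O)/C=C/C(C)(C)C/C=C(\C)CC/C=C/4C)nn3)cc2O)c1` carries 3-methoxyphenyl and gives 0.95 ug/mL. Compound 3 `COc1ccccc1/C=C/C(=O)c1ccc(OCCn2cc(CN3C(=O)/C=C/C(C)(C)C/C=C(\C)CC/C=C/3C)nn2)cc1O` carries 2-methoxyphenyl and gives 0.9 ug/mL, the lowest number of the three, but its gap to compound 2 is within the scatter; only the gap to compound 1 is beyond it, as a 3.6-fold lower number from compound 1 to compound 3 (0.56 log units; beyond the scatter) and a 3.4-fold lower number from compound 1 to compound 2 (0.53 log units; beyond the scatter) show, while a 1.1-fold lower number from compound 2 to compound 3 (0.02 log units; within the scatter) is flat.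

Compound 4 `COc1cc(/C=C/C(=O)c2ccc(OCCn3cc(CN4C(=O)/C=C/C(C)(C)C/C=C(\C)CC/C=C/4C)nn3)cc2O)cc(OC)c1OC` is the next step: 3,4,5-trimethoxyphenyl in place of 2-methoxyphenyl on a double-bonded chain carbon bound to a double-bonded chain carbon. Among the compounds with values here, no measured step adds methoxy groups; the measured steps move a single methoxy around the ring. Within the data shown here, of those, the one that bears on compound 4 is the presence of the 4-methoxyphenyl pattern in compound 1, which gives 3.24 ug/mL, the weakest number so far, whereas the entering group also holds the pattern of compound 2, which gives 0.95 ug/mL.

Compound 4 is therefore expected to land between compound 1 and compound 3, a modest rise in number, a 2.2-fold higher number from compound 3 to compound 4 (0.35 log units; beyond the scatter). Compound 4 is estimated at 2 ug/mL, within 0.8 ug/mL to 5 ug/mL.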

Compound 4, half-maximal inhibitory concentration: 2.61 ug/mL
The estimate for compound 4 lay 1.3-fold (0.12 log units) below the measured number; the range from low to high includes it.
By their numbers in this assay, from the lowest: compounds 3 and 2 (each within the scatter of the next); then compounds 4 and 1 (each within the scatter of the next).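

Working notes: the 3,4,5-trimethoxyphenyl group does not keep the low numbers of the single-methoxy groups in compounds 2 and 3, as a 2.9-fold higher number from compound 3 to compound 4 (0.46 log units; beyond the scatter) and a 2.7-fold higher number from compound 2 to compound 4 (0.44 log units; beyond the scatter) show together. It instead stays level with the 4-methoxyphenyl group (a 1.2-fold lower number from compound 1 to compound 4 (0.09 log units; within the scatter)), so the four aryl groups at this position form two pairs, compounds 2 and 3 on the lower side and compounds 1 and 4 on the higher side, and both groups of the higher pair carry a 4-methoxy pattern in their names, while compound 4 also carries the 3-methoxy pattern of compound 2 and still does not group with compound 2. No supporting measurement is available to explain why these groups divide this way.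

Going by these compounds, whether the 4-methoxy pattern alone sets the higher number stays open, and a 3,5-dimethoxyphenyl group at this position would separate it from the other two methoxy groups of compound 4. On these data alone, how much any methoxy group matters here also stays open, since an unsubstituted phenyl or a 4-hydroxyphenyl group would be needed to set a baseline for the series.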